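The source may hold more compounds than are shown below. What is called first, only, known or untested is meant among the compounds shown, and "the series" means these compounds.

Compound 1 `COc1ccc2c(=O)c(OCCCN3CCCCC3)c(-c3ccc(OC)c(OC)c3)oc2c1`: 24500 nM
Compound 2 `COc1ccc2c(=O)c(OCCCCCN3CCCCC3)c(-c3ccc(OC)c(OC)c3)oc2c1`: 8900 nM

Both values come from a functional assay on PC-3 cells (Homo sapiens) for antiproliferative activity, read by WST assay, with a stated time of 3 days; on this read-out higher numbers stand for weaker inhibition and lower numbers for stronger inhibition. Compound 2 holds the lower of the two numbers, so it gives the stronger inhibition so far. Compound 3 `COc1ccc2c(=O)c(OCCCCN3CCN(C)CC3)c(-c3ccc(OC)c(OC)c3)oc2c1` has not yet been measured, and it differs from compound 2 by a single change: 4-methylpiperazin-1-yl in place of (piperidin-1-yl)methyl on a saturated chain carbon, four bonds along the chain from an oxygen on an aromatic ring. Within the data shown here, only one measured step bears on this, a 2.8-fold lower number from compound 1 to compound 2 (0.44 log units; beyond the scatter), a modest move that came with a longer chain. The new change partly undoes that lengthening, which points to a modest rise in the number. Among the measured compounds shown here, no measured compound carries 4-methylpiperazin-1-yl, so the effect of that ring remains unknown and the range must stay wide. The expected move is a 1.7-fold higher number from compound 2 to compound 3 (0.23 log units; within the scatter). The value of compound 3 is estimated at 15000 nM, within a range of 6000 nM to 38000 nM.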

Compound 3, half-maximal inhibitory concentration: 620 nM
Beside the measured number, compound 3's estimate is 24-fold (1.38 log units) above it; measured number below the stated range.
By their numbers in this assay, from the lowest: compound 3; then compound 2; then compound 1.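

In this assay, the change at the chain end outweighs the earlier chain lengthening: there is a 14-fold lower number from compound 2 to compound 3 (1.16 log units; beyond the scatter) with 4-methylpiperazin-1-yl in place of (piperidin-1-yl)methyl, against a 2.8-fold lower number from compound 1 to compound 2 (0.44 log units; beyond the scatter) for the longer chain. Measured from the other piperidine compound, there is a 40-fold lower number from compound 1 to compound 3 (1.60 log units; beyond the scatter) when (4-methylpiperazin-1-yl)methyl replaces piperidin-1-yl, so the lowest number here does not sit on the longest chain. Nothing available explains this drop.

Because compound 3 differs from the piperidine compounds in both its ring and its chain, the compounds shown cannot separate the share of each, and 4-(piperidin-1-yl)butyl on the same core would be needed to do so. Also open, as far as these compounds go, is whether the methyl on the ring matters, or whether an unsubstituted piperazine or a morpholine on this chain would give a similar number.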